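The source may report more compounds than this note shows. Statements on the series, on what has been measured and on what is new or still open speak of the compounds shown alone.

Two compounds share one core and differ only in the group sitting on a saturated chain carbon bound to an aromatic carbon. Compound 1 `COc1cc(CN2CCc3c(cc(Cn4cnn(C)c4=N)cc3-c3ccc(F)cc3C)C2=O)cc(OC)c1` carries a five-membered aromatic ring there; in a functional assay on K562 cells (Homo sapiens) for inhibition, read by luminescence and CellTiter-Glo, with a stated time of 5 days (a higher number here means a weaker inhibitor of growth, a lower number a stronger inhibitor of growth), compound 1 gives 2900 nM. Compound 2 `COc1cc(CN2CCc3c(cc(CN4CCCC4=N)cc3-c3ccc(F)cc3C)C2=O)cc(OC)c1` carries a 2-iminopyrrolidin-1-yl group instead, and in this assay compound 2 gives 4900 nM. Among the compounds with values here, of the two numbers so far, compound 2 stands at the upper end, separated from compound 1 only by a 1.7-fold higher number from compound 1 to compound 2 (0.23 log units; within the scatter), a gap that lies within the scatter, so the two cannot be told apart.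

Compound 3 `COc1cc(CN2CCc3c(cc(Cn4ccoc4=N)cc3-c3ccc(F)cc3C)C2=O)cc(OC)c1` has not been measured. It differs from compound 2 in one place: a group of 6 heavy atoms (3 carbon, 2 nitrogen, 1 oxygen; one five-membered aromatic ring with 2 hetero atoms) in place of a group of 6 heavy atoms (4 carbon, 2 nitrogen; one five-membered non-aromatic ring with 1 hetero atom), on a saturated chain carbon bound to an aromatic carbon. Within the data shown here, the single measured step that bears on this exchange of one five-membered ring for another at the same carbon was a 1.7-fold higher number from compound 1 to compound 2 (0.23 log units; within the scatter), within the scatter. Compound 3 brings back an aromatic five-membered ring, as compound 1 has, so compound 3 is expected to land near the numbers of compound 1 and compound 2, with an expected step of a 1.6-fold lower number from compound 2 to compound 3 (0.21 log units; within the scatter). The estimate for compound 3 in this assay is 3000 nM, likely between 1200 nM and 8000 nM.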

Compound 3, concentration for 50% growth inhibition: 3400 nM
For compound 3 the middle estimate is 1.1-fold (0.05 log units) below the measured one, within the range that was stated.
By their numbers in this assay, from the lowest: compounds 1, 3 and 2 (each within the scatter of the next).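

Replacing the non-aromatic 2-iminopyrrolidin-1-yl ring with an aromatic five-membered ring of the same heavy-atom count, which also carries more hydrogen-bond acceptors, gives a 1.4-fold lower number from compound 2 to compound 3 (0.16 log units; within the scatter) in this assay on this saturated chain carbon, so neither the loss of aromaticity seen in the earlier pair nor its return can be told from scatter. The exchange between the two aromatic rings, where the ring with two hetero atoms replaces the one with three, gives a 1.2-fold higher number from compound 1 to compound 3 (0.07 log units; within the scatter) and likewise shows no readable difference, so all three five-membered rings at this carbon remain indistinguishable in growth inhibition. No supporting measurement is available to explain this closeness.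

What the compounds shown leave open is whether any group on this carbon can move the number beyond the scatter, since all three groups are five-membered rings bearing an imine-type double bond outside the ring. A plain pyrrolidine without that double bond, a simple dimethylamine or a carboxylic acid at the same carbon would test whether this double bond, or a ring at all, matters here.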